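Cyclohexyl in place of ethyl on the urea nitrogen

The compounds below may be only part of what the source reports. "The series", "measured", "known", "first", "only" and "open" are said of these compounds alone.

Compound 1 `NC(=O)N1CCN(C(=S)SCc2cn(Cc3ccccc3F)nn2)CC1`: in a functional assay on SMMC-7721 cells (Homo sapiens) for cytotoxicity, read by MTT assay, with a stated time of 72 h (a lower number here means a stronger inhibitor, a higher number a weaker inhibitor), compound 1 gives > 128000 nM, a limit of the assay.
Compound 2 `CCNC(=O)N1CCN(C(=S)SCc2cn(Cc3ccccc3F)nn2)CC1`: in this assay compound 2 gives > 128000 nM, again a limit.
Compound 3 `CCNC(=O)N1CCN(C(=S)SCc2cn(Cc3ccc(F)cc3)nn2)CC1`: in this assay compound 3 gives 44400 nM.

Compound 3 is the only one of the three with a measured number; the other two stand at the limit of > 128000 nM in this assay, at which 2 of the 3 values shown sit. The step that the two limits leave unreadable from compound 1 to compound 2, which is an exchange on the amide-type nitrogen, cannot be read from those two limits. The step of an at least 2.8-fold lower number from compound 2 to compound 3 (0.45 log units; beyond the scatter), on the saturated chain carbon bound to an aromatic nitrogen, is the only readable one and concerns a different part of the molecule.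

Compound 4 `O=C(NC1CCCCC1)N1CCN(C(=S)SCc2cn(Cc3ccc(F)cc3)nn2)CC1` differs from compound 3 by cyclohexyl in place of ethyl on an amide-type nitrogen. Going by the values given here, the one measured step at this nitrogen is unreadable, and no measured compound carries a cyclohexyl there, so nothing among the known steps points in either direction. The expected step of a 1.1-fold lower number from compound 3 to compound 4 (0.05 log units; within the scatter) is therefore set at none beyond the scatter, with a wide margin of doubt. Compound 4 is estimated at 40000 nM in this assay, with a range from 10000 nM to 128000 nM, and a real chance that only a limit is returned.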

Compound 4, half-maximal inhibitory concentration: > 128000 nM
Compound 4 gave a limit, no number (the forecaster's own chance of this, stated with the estimate: 25%); middle value at least 3.2-fold (0.50 log units) from the limit.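

Going by these compounds alone, the earlier step at this amide-type nitrogen could not be read, as both of its compounds stood at limits, so this is the first readable evidence that the group there matters. In this assay, cyclohexyl in place of ethyl on this nitrogen gives an at least 2.8-fold higher number from compound 3 to compound 4 (0.45 log units; beyond the scatter), which lies beyond the scatter and runs towards the weaker end of the read-out, so the larger ring-bearing group does not preserve the modest activity of the ethyl compound that carries the 4-fluorophenyl group. Compound 3 remains the only compound shown with a number, which leaves the series with a single measured point: the limit of > 128000 nM in this assay, at which 3 of the 4 values shown sit.

As far as these compounds go, the full size of this step remains open, as does the question of whether a methyl, a propyl or a phenyl on this nitrogen would give a number higher or lower than that of compound 3. From the compounds shown here alone, it is also open whether a smaller ring such as cyclopropyl would behave like ethyl or like cyclohexyl, and whether the 4-fluorophenyl group would still yield a measurable value with such groups in place.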